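Amide variation on the shared core: outlook for compound 3

The source may report more compounds than this note shows. Statements on the series, on what has been measured and on what is new or still open speak of the compounds shown alone.

compound 1 `CCn1c(C(=O)NCCN(C)C)ccc1C(CC)(CC)c1ccc(OCC(=O)C(C)(C)C)c(C)c1` — 2300 nM
compound 2 `C#CCNC(=O)c1ccc(C(CC)(CC)c2ccc(OCC(O)C(C)(C)C)c(C)c2)n1CC` — > 50000 nM

Of the compounds shown here, two have been measured in a functional assay on HepG2 cells (Homo sapiens), read by MTT assay, with a stated time of 48 h; on this read-out lower numbers stand for stronger inhibition and higher numbers for weaker inhibition. Compound 1 `CCn1c(C(=O)NCCN(C)C)ccc1C(CC)(CC)c1ccc(OCC(=O)C(C)(C)C)c(C)c1` gives a numerical value there, 2300 nM. Compound 2 `C#CCNC(=O)c1ccc(C(CC)(CC)c2ccc(OCC(O)C(C)(C)C)c(C)c2)n1CC` returns no number in this assay but only a limit, > 50000 nM, as recorded in the note that (the limit of > 50000 nM in this assay, at which 1 of the 2 values shown sits). Among the compounds with values here, compounds 1 and 2 differ in more than one place, so no single step between them is measured; their two values show only that compound 1 sits within the measured range while compound 2 does not.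

Compound 3 `CCn1c(C(=O)N(CCC#N)CCC#N)ccc1C(CC)(CC)c1ccc(OCC(O)C(C)(C)C)c(C)c1` is not yet measured. It differs from compound 2 by a group of 9 heavy atoms (6 carbon, 3 nitrogen; no ring) in place of a group of 4 heavy atoms (3 carbon, 1 nitrogen; no ring), on a carbonyl carbon. Within the data shown here, no measured step of this kind exists, so the expectation rests solely on where compound 2 stands, which is at the limit. Compound 3 is therefore expected to give about 60000 nM in this assay, with a range from 15000 nM to 200000 nM. The implied step that the limit leaves unreadable from compound 2 to compound 3 is expected to be none beyond the scatter, and a further limit rather than a number is the likelier outcome.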

Compound 3, half-maximal inhibitory concentration: 42000 nM
Compound 3: middle estimate off by 1.4-fold (0.15 log units), on the high side, within the range that was stated.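

The carbonyl carbon of the shared core now has a reading on both sides of the assay limit. In this assay, compound 3 gives 42000 nM, and exchanging propargylamino for the group of 9 heavy atoms yields an at least 1.1-fold lower number from compound 2 to compound 3 (0.07 log units; that floor lies within the scatter). This exchange removes the single hydrogen-bond donor of propargylamino, as the entering group has 0 hydrogen-bond donors, and the assay still returns a number, although this one pair cannot tie that count to the read-out. Compound 2 has only a limit, so the size of the step remains bounded on one side and no real gain can be claimed from it: the limit of > 50000 nM in this assay, at which 1 of the 3 values shown sits.

Going by these compounds, it remains open whether a smaller group on the same carbonyl carbon, such as dimethylamino, or one with a single 2-cyanoethyl chain, would give a number in this assay and whether either nitrile-bearing chain matters on its own. Also open, on these data alone, is how 2-(dimethylamino)ethylamino reads with the hydroxyl-bearing side chain of compound 2 and compound 3, which would set that amide group against the others in a single-place comparison.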